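The compounds below may be only part of what the source reports. "The series", "measured", "known", "first", "only" and "open" are said of these compounds alone.

Measured in a functional assay (aorta) with Oryctolagus cuniculus as the target; a lower number here means tighter binding, a higher number weaker binding:
- compound 1 `COc1cc(C(C)=O)ccc1OCCCN1CCC(C(c2ccc(F)cc2)c2ccc(F)cc2)CC1`: 1.59 nM
- compound 2 `COc1cc(C(C)=O)ccc1OCCCN1CCC(C(N)(c2ccc(F)cc2)c2ccc(F)cc2)CC1`: 31.6 nM

Among the measured compounds shown here, compound 2 stands at the higher of the two numbers, and its only measured neighbour is compound 1. For the measured compounds named here, the one measured step is large: a 20-fold higher number from compound 1 to compound 2 (1.30 log units; beyond the scatter). It came from amino in place of hydrogen on a saturated chain carbon bound to two aromatic carbons and a saturated ring carbon.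

Compound 3 `COc1cc(C(C)=O)ccc1OCCCN1CCC(C(NC(C)=O)(c2ccc(F)cc2)c2ccc(F)cc2)CC1` keeps the shared core and changes that amino group to acetamido, with acetyl in place of hydrogen on an amine nitrogen. Going by the values given here, no measured step covers a change on this nitrogen, so the evidence is indirect. Among the compounds with values here, the step of a 20-fold higher number from compound 1 to compound 2 (1.30 log units; beyond the scatter) shows only that a change in this part of compound 2 can move the number a long way. It gives no direction for the acetyl change. No step beyond the scatter is therefore expected, though the uncertainty is wide and runs both ways. The expected step is a 1.6-fold lower number from compound 2 to compound 3 (0.20 log units; within the scatter). For compound 3 the estimated value is 20 nM, with an expected range of 4 nM to 100 nM.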

Compound 3, dissociation constant: 63.1 nM
Beside the measured number, compound 3's estimate is 3.2-fold (0.50 log units) below it, within the range that was stated.
By their numbers in this assay, from the lowest: compound 1; then compounds 2 and 3 (each within the scatter of the next).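

Working notes on the amine nitrogen: in this assay, acetyl in place of hydrogen on this nitrogen gives a 2.0-fold higher number from compound 2 to compound 3 (0.30 log units; within the scatter), so this read-out does not separate amino from acetamido at this position. The large penalty seen with amino therefore stays in place once the nitrogen carries acetyl, with a 40-fold higher number from compound 1 to compound 3 (1.60 log units; beyond the scatter) set against a 20-fold higher number from compound 1 to compound 2 (1.30 log units; beyond the scatter), and both groups on the saturated chain carbon stand beyond the scatter from the hydrogen of compound 1. No supporting measurement is available that would explain either the large steps from compound 1 or the absence of a step beyond the scatter on acetylation.

Still open, on these data alone, is whether any other group on the saturated chain carbon, such as a hydroxyl or a methyl, would stay within the scatter of compound 1, which would show whether the penalty follows the nitrogen or any replacement of the hydrogen. Also open, as far as these compounds go, is whether a longer acyl chain or a methanesulfonyl group on the amine nitrogen would remain within the scatter of compound 2 and compound 3 or move the number further from compound 1.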